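This account rests on a few compounds, and the source may have more. Where it says the series, first, only, none or still open, it means among the compounds named here.

Two compounds have been measured in an assay on Sf9 cells for inhibition of protein deacetylase HDAC6 (Homo sapiens), read by fluorescence; a lower number here means a stronger inhibitor, a higher number a weaker inhibitor:

Compound 1: `Cn1c(Sc2c(F)cc(C(=O)NO)cc2F)nnc1-c1cccs1`, 9 nM
Compound 2: `Cn1c(Sc2c(F)cc(C(=O)NO)cc2F)nnc1-c1cccnn1`, 13 nM

Compound 2 stands beside compound 1 with nothing to separate them, the step of a 1.4-fold higher number from compound 1 to compound 2 (0.16 log units; within the scatter) lying within the scatter. Compound 3 is `Cn1c(Sc2c(F)cc(C(=O)NO)cc2F)nnc1-c1ncccc1F`; it differs from compound 2 by 3-fluoropyridin-2-yl in place of pyridazin-3-yl on an aromatic carbon. Going by the values given here, the only step that bears on this change is the one from compound 1 to compound 2, where another aromatic ring was exchanged at the same carbon, and it was a 1.4-fold higher number from compound 1 to compound 2 (0.16 log units; within the scatter). On that basis no shift beyond the scatter is expected in this assay. Compound 3 is therefore estimated at 13 nM, with a range from 5 nM to 35 nM. The step of no change at the digits printed from compound 2 to compound 3 (within the scatter) is expected to remain within the scatter.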

Compound 3, half-maximal inhibitory concentration: 6 nM
Beside the measured number, compound 3's estimate is 2.2-fold (0.34 log units) above it; the range from low to high includes it.
By their numbers in this assay, from the lowest: compounds 3, 1 and 2 (each within the scatter of the next, the first and the last beyond it).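

In this assay, this carbon of the five-membered ring now shows a step beyond the scatter between two aromatic rings: 3-fluoropyridin-2-yl in place of pyridazin-3-yl gives a 2.2-fold lower number from compound 2 to compound 3 (0.34 log units; beyond the scatter) on the shared core. Set against thiophen-2-yl, the same group gives a 1.5-fold lower number from compound 1 to compound 3 (0.18 log units; within the scatter) and so cannot be told apart from it. Nothing available explains the step. Still open, on these data alone, is whether an amine or a saturated cyclohexyl ring at this carbon would keep such numbers. Also open, as far as these compounds go, is whether pyridin-2-yl, without the fluorine, would do the same.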